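Fluoro gives way to cyano on compound 3

A few compounds are considered here, and "the series" means these few. Any claim that something is new, unique, unknown or untested is made for them only; others in the source may bear on it.

Compound 1 `C#C[C@@]1(O)[C@H](O)[C@@H](CO)O[C@H]1n1ccc(N)nc1=O`: > 100000 nM, a limit
Compound 2 `C#C[C@@]1(O)[C@H](O)[C@@H](CO)O[C@H]1n1cnc2c(=O)[nH]c(N)nc21`: > 100000 nM, a limit
Compound 3 `C#C[C@@]1(O)[C@H](O)[C@@H](CO)O[C@H]1n1cc(F)c2c(N)ncnc21`: 44000 nM

All three compounds were tested in an ADME assay on A549 cells (Homo sapiens) for cytotoxicity, read by luminescence, CellTiter-Glo and ATP content; a higher number here means that more compound is tolerated, a lower number that less compound is tolerated. Going by the values given here, compound 3, at 44000 nM, is the only one with a number rather than a limit. Compound 1 and compound 2 stand at the limit of > 100000 nM in this assay, at which 2 of the 3 values shown sit.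

Compound 4 `C#C[C@@]1(O)[C@H](O)[C@@H](CO)O[C@H]1n1cc(C#N)c2c(N)ncnc21` has cyano in place of fluoro on an aromatic carbon. Among the compounds with values here, no measured pair shows what such a change does in this assay, so no step beyond the scatter is expected. The estimated step of a 1.4-fold higher number from compound 3 to compound 4 (0.13 log units; within the scatter) is small, leaning slightly toward more compound being tolerated. For compound 4 the expected value is 60000 nM, with an estimated range of 15000 nM to 100000 nM.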

Compound 4, half-maximal cytotoxic concentration: > 100000 nM
Compound 4 gave a limit, no number (the forecaster's own chance of this, stated with the estimate: 40%); middle value at least 1.6-fold (0.22 log units) away from the limit.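

Going by these compounds alone, at this position, on the aromatic carbon two ring bonds from the ring nitrogen, the earlier compounds gave no measured change, whereas cyano in place of fluoro now gives a step beyond the scatter in this assay: an at least 2.2-fold higher number from compound 3 to compound 4 (0.35 log units; beyond the scatter). Compound 4 gives > 100000 nM, which is a limit and not a number. The step is therefore only a lower bound, and compound 4 now sits with compound 1 and compound 2: the limit of > 100000 nM in this assay, at which 3 of the 4 values shown sit.

Going by these compounds, whether chloro, methyl or an amine on this carbon would stay at that limit or fall back toward compound 3 remains open.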